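The source may hold more compounds than are shown below. What is called first, only, known or untested is meant among the compounds shown, and "the series" means these compounds.

Measured compounds:

Compound 1, `COc1cc2c(Oc3ccc(NC(=O)c4cc(-c5ccccc5)ccn4)cc3F)ccnc2cc1OCCCN1CCN(C)CC1`, gives 82 nM.
Compound 2, `COc1cc2c(Oc3ccc(NC(=O)c4cc(-c5ccccc5F)ccn4)cc3F)ccnc2cc1OCCCN1CCN(C)CC1`, gives 220 nM.
Compound 3, `COc1cc2c(Oc3ccc(NC(=O)c4nccc(-c5ccc(F)cc5)n4)cc3F)ccnc2cc1OCCCN1CCCCC1`, gives 120 nM.

All three numbers come from a functional assay on HT-29 cells (Homo sapiens) for cytotoxicity, read by MTT assay, with a stated time of 72 h; a lower number here means a stronger inhibitor, a higher number a weaker inhibitor. Compound 1 and compound 2 share one core and differ in a single place: fluoro in place of hydrogen on an aromatic carbon. That change gave a 2.7-fold higher number from compound 1 to compound 2 (0.43 log units; beyond the scatter), so the added fluorine weakened the compound by a modest but real amount.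

Compound 3 rests on a different core; how its core differs from that of compound 1 is not broken down here. Its value sits close to compound 1, and the two cannot be told apart within the scatter of this assay.

The unmeasured compound 4, `COc1cc2c(Oc3ccc(NC(=O)c4nccc(-c5ccc(F)cc5F)n4)cc3F)ccnc2cc1OCCCN1CCCCC1`, is made from compound 3 by the same kind of change: fluoro in place of hydrogen on an aromatic carbon. The surroundings are not identical. In compound 4 the new fluoro also stands meta to a fluoro group, while in compound 2 the place is only ortho to a large group. Among the compounds with values here, still, the only measured precedent is the step from compound 1 to compound 2, and the expectation for compound 4 follows that precedent, somewhat softened for the different setting. The step estimated for compound 4 is a 1.8-fold higher number from compound 3 to compound 4 (0.26 log units; within the scatter), resting on a 2.7-fold higher number from compound 1 to compound 2 (0.43 log units; beyond the scatter). Compound 4 is therefore expected to give about 220 nM, most likely between 100 nM and 500 nM.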

Compound 4, half-maximal inhibitory concentration: 400 nM
Compound 4: the middle estimate sits 1.8-fold (0.26 log units) below what was measured; the measured number falls inside the stated range.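

In this assay, turning the 4-fluorophenyl group into a 2,4-difluorophenyl group gave a 3.3-fold higher number from compound 3 to compound 4 (0.52 log units; beyond the scatter), so the added fluoro group made the compound a weaker inhibitor by a modest but real amount. The same change has now been seen on two cores, and the two steps agree in direction and cannot be told apart in size: the same change on two cores in this assay, a 2.7-fold higher number (0.43 log units; beyond the scatter) from compound 1 to compound 2 and a 3.3-fold higher number (0.52 log units; beyond the scatter) from compound 3 to compound 4, 1.2-fold (0.09 log units) apart, within the scatter of two such steps This shows that, in these two pairs, a fluoro group placed ortho to a large group carried over from one core to the other, but two pairs are too few to make a rule for the whole series, and the numbers do not explain why the inhibitor weakens.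

The compounds shown leave open whether a chloro group, a methyl group or a nitrile in the same place would give a similar step, or whether the result is particular to fluoro. Going by these compounds, it also remains open whether the step would keep its size on a core other than these two.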